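Swapping a Cyanophenyl Arm for a Phenylethenyl Arm

The source may hold more compounds than are shown below. What is called first, only, known or untested is meant among the compounds shown, and "the series" means these compounds.

Compound 1 `CCCCN1CCC(C(=O)Nc2cc(Cl)c(N)cc2OC)CC1`: in a functional assay on the whole organism for antagonist activity, with Mus musculus as the target (on this read-out higher numbers stand for an effect only at larger amounts of compound and lower numbers for an effect already at smaller amounts), compound 1 gives > 10 mg/kg, which is a limit of the assay and not a number.
Compound 2 `COc1cc(N)c(Cl)cc1NC(=O)C1CCN(CC2CCCCCC2)CC1`: in this assay compound 2 gives > 10 mg/kg, again only a limit.
Compound 3 `COc1cc(N)c(Cl)cc1NC(=O)C1CCN(Cc2cccc(C#N)c2)CC1`: in this assay compound 3 gives > 4 mg/kg, also only a limit.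

Compound 3 therefore stands nowhere definite on the numbers shown: every measured value is a limit, namely the limit of > 10 mg/kg in this assay, at which 2 of the 3 values shown sit, and (the limit of > 4 mg/kg in this assay, at which 1 of the 3 values shown sits). The three single-point changes among the measured compounds, a step that the two limits leave unreadable from compound 1 to compound 2, a step that the two limits leave unreadable from compound 1 to compound 3 and a step that the two limits leave unreadable from compound 2 to compound 3, are all unreadable in size for the same reason, so no measured step gives a readable direction.

Compound 4 `COc1cc(N)c(Cl)cc1NC(=O)C1CCN(C/C=C/c2ccccc2)CC1` differs from compound 3 by 2-phenylethenyl in place of 3-cyanophenyl on a saturated chain carbon bound to an amine nitrogen in a ring. Going by the values given here, since no step among the measured compounds bears on this change in a readable way, no step beyond the scatter is expected in either direction: the estimated step that the limit leaves unreadable from compound 3 to compound 4 is taken as roughly flat. Compound 4 is thus expected to give about 8 mg/kg in this assay, within a wide range from 2 mg/kg to 30 mg/kg, and most likely only a limit will be reported.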

Compound 4, dose for half-maximal effect: > 10 mg/kg
Compound 4 gave a limit, no number; the forecaster's own chance of this, stated with the estimate: 70%; middle value at least 1.2-fold (0.09 log units) away from the limit.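

In this assay compound 4 gives > 10 mg/kg, again only a limit. The steps to compound 4 from compound 1, compound 2 and compound 3 therefore cannot be read in size. The compounds shown leave open what dose of any of them gives half-maximal effect, and whether changing the group alters that dose at all.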